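The source may hold more compounds than are shown below. What is called first, only, known or untested is meant among the compounds shown, and "the series" means these compounds.

Measured compounds:
compound 1, `Cn1c(-c2ccc(NC(=O)CCl)cc2)nc(-c2ccccc2)c1-c1ccccc1`, in a functional assay on MCF7 cells (Homo sapiens) for cytotoxicity, read by MTT assay, with a stated time of 24 h, tested at 80 ug/mL (a higher number here means a stronger effect of the compound at the concentration tested, a lower number a weaker effect), gives 70%
compound 2, `Cn1ccnc1SCC(=O)Nc1ccc(-c2nc(-c3ccccc3)c(-c3ccccc3)n2C)cc1`, in this assay gives 64%
compound 3, `CN1CCN(CC(=O)Nc2ccc(-c3nc(-c4ccccc4)c(-c4ccccc4)n3C)cc2)CC1`, in this assay gives 50.3%

Compound 3 stands lowest of the three. One step down to it is a number 13.7 percentage points lower from compound 2 to compound 3 (beyond the scatter), and the other is a number 19.7 percentage points lower from compound 1 to compound 3 (beyond the scatter), both beyond the scatter, so it is the weakest of the three measured compounds at the tested concentration.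

Compound 4 is `Cn1c(-c2ccc(NC(=O)CN3CCN(Cc4ccccc4)CC3)cc2)nc(-c2ccccc2)c1-c1ccccc1`. It differs from compound 3 only by phenyl in place of hydrogen on a saturated chain carbon bound to an amine nitrogen in a ring. Among the compounds with values here, none of the measured steps touches this part of the molecule: a number 6 percentage points lower from compound 1 to compound 2 (within the scatter) and the two steps to compound 3 all exchange the group on the saturated chain carbon bound to the carbonyl carbon, and the 4-methylpiperazin-1-yl group of compound 3 itself appears only once. There is thus no directly comparable step, and the expectation for compound 4 rests on compound 3 alone, with no clear reason for a shift beyond the scatter in either direction. The estimated step is a number 2.7 percentage points higher from compound 3 to compound 4 (within the scatter). For compound 4 the estimate in this assay is 53%, with a range from 36% to 70%.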

Compound 4, a percentage reported as activity, at one concentration (the size of the read-out at that concentration, not a potency): 49.5%
Compound 4: the middle estimate sits 3.5 percentage points above what was measured, within the range that was stated.
By their numbers in this assay, from the lowest: compounds 4 and 3 (each within the scatter of the next); then compounds 2 and 1 (each within the scatter of the next).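

Every earlier step exchanged the whole group on the saturated chain carbon bound to a carbonyl carbon, whereas this one leaves that group's ring in place and alters only its outer end, from methyl to benzyl. Putting phenyl in place of hydrogen on a saturated chain carbon bound to an amine nitrogen in a ring gives, in this assay, a step of a number 0.8 percentage points lower from compound 3 to compound 4 (within the scatter), so for this pair the added aromatic ring leaves the read-out indistinguishable. Nothing available explains why the two compounds read alike.

From the compounds shown here alone, whether a longer chain before the phenyl ring, or a carboxylic acid or an amine on that ring, would move the number stays open. Readings at a single concentration also leave open whether compound 3 and compound 4 match in potency.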